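The source may hold more compounds than are shown below. What is called first, only, known or untested is meant among the compounds shown, and "the series" means these compounds.

Compound 1 `C/C=C(\CC)Oc1cc(C)nc(Oc2c(C)cc(C)cc2C)c1C` gives 55% in a functional assay on the whole organism for displacement of a labelled ligand, with Rattus norvegicus as the target, at a dose of 3.2 mg/kg by the subcutaneous route; on this read-out higher numbers stand for more inhibition at the one dose given (going by the name of the read-out) and lower numbers for less inhibition.
Compound 2 `CCC(C)Oc1cc(C)nc(Oc2c(C)cc(C)cc2C)c1C` gives 42% in this assay.

Compound 2 stands lowest of the two measured numbers, separated from compound 1 by a number 13 percentage points lower from compound 1 to compound 2 (beyond the scatter). Compound 3 `CCC(COC)Oc1cc(C)nc(Oc2c(C)cc(C)cc2C)c1C` differs from compound 2 by methoxy in place of hydrogen on a saturated chain carbon, two bonds along the chain from an oxygen on an aromatic ring. For the measured compounds named here, no measured step concerns a change of this kind; the only step on record swaps one whole group for another on the oxygen on the aromatic ring and offers little guidance here. The step in this assay is therefore expected to be a number 2 percentage points lower from compound 2 to compound 3 (within the scatter), within the scatter. Compound 3 is estimated at 40%, with a range from 20% to 60%.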

Compound 3, a percentage reported as inhibition, in the whole organism at one dose (the size of the read-out at that dose, not a potency): 49%
For compound 3 the middle estimate is 9 percentage points below the measured one; the measured number falls inside the stated range.
By their numbers in this assay, from the lowest: compounds 2, 3 and 1 (each within the scatter of the next, the first and the last beyond it).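

In this assay the methoxy on this saturated chain carbon gives a number 7 percentage points higher from compound 2 to compound 3 (within the scatter) and so does not shift the read-out beyond the scatter. The exchange of whole groups on the oxygen gives a number 6 percentage points lower from compound 1 to compound 3 (within the scatter) and shows that 1-(methoxymethyl)propyl, unlike sec-butyl, stays within the scatter of 1-ethylprop-1-en-1-yl. Nothing at hand explains this result.

The compounds shown leave open how a hydroxyl or an amine on the same carbon would read. They also leave open whether a longer ether chain would match methoxy.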